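From compound 3 to compound 4: a series at its limit

The source may report more compounds than this note shows. Statements on the series, on what has been measured and on what is new or still open speak of the compounds shown alone.

In an ADME assay on microsomes from liver (Canis lupus familiaris) for metabolic stability (a lower number here means that the compound disappears faster, a higher number that the compound lasts longer), compound 1 `Nc1nc(NCCNc2ncc(-c3ncc[nH]3)c(-c3ccc(F)cc3F)n2)ccc1[N+](=O)[O-]` gives > 0.5 h, which is a limit. Compound 2 `Nc1nc(NCCNc2ncc(-c3ncc[nH]3)c(-c3cc(F)ccc3F)n2)ccc1[N+](=O)[O-]` gives > 0.5 h, also a limit. Compound 3 `Nc1nc(NCCNc2ncc(-c3ncc[nH]3)c(-c3cc(F)c(F)cc3F)n2)ccc1[N+](=O)[O-]` gives > 0.5 h, again a limit and not a number. The series therefore stands at one mark: the limit of > 0.5 h in this assay, at which 3 of the 3 values shown sit. Next comes compound 4 `Nc1nc(NCCNc2ncc(-c3ncc[nH]3)c(-c3ccc(F)cc3C(F)(F)F)n2)ccc1[N+](=O)[O-]`, with 4-fluoro-2-(trifluoromethyl)phenyl in place of 2,4,5-trifluorophenyl on an aromatic carbon. The measured steps that bear on this are a step that the two limits leave unreadable from compound 1 to compound 2, a step that the two limits leave unreadable from compound 1 to compound 3 and a step that the two limits leave unreadable from compound 2 to compound 3. None of them gives a size, so no step beyond the scatter is expected, and no direction. The expected step is a step that the limit leaves unreadable from compound 3 to compound 4. For compound 4 the estimate is 0.8 h, with an expected range of 0.4 h to 2 h.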

Compound 4, half-life: > 0.5 h
Compound 4: a limit, no number (the forecaster's own chance of this, stated with the estimate: 75%); the middle value lies beyond the limit too.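

Compound 4 gives > 0.5 h as a limit and not a number, and none of its steps from compound 1, compound 2 or compound 3 can be read. In this assay the compounds shown leave open whether these phenyl groups differ at all: the limit of > 0.5 h in this assay, at which 4 of the 4 values shown sit.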